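Cytotoxicity notes: from compound 1 toward compound 4

This account rests on a few compounds, and the source may have more. Where it says the series, first, only, none or still open, it means among the compounds named here.

Measured compounds:
compound 1 `CS(=O)(=O)Nc1ccc2c(c1)S(=O)(=O)N=C(C1=C(O)C3CCCC3N(CCC3CC3)C1=O)N2` — > 33000 nM
compound 2 `CS(=O)(=O)Nc1ccc2c(c1)S(=O)(=O)N=C(C1=C(O)[C@H]3CCC[C@H]3N(Cc3ccc(F)c(Cl)c3)C1=O)N2` — > 1000 nM
compound 3 `CS(=O)(=O)Nc1ccc2c(c1)S(=O)(=O)N=C(C1=C(O)[C@H]3CCCC[C@H]3N(Cc3ccc(F)cc3)C1=O)N2` — > 1000 nM

In an ADME assay on Huh-7 cells (Homo sapiens) for cytotoxicity, with a stated time of 72 h (a lower number here means that less compound is tolerated, a higher number that more compound is tolerated), compound 1 gives > 33000 nM, which is a limit of the assay and not a number. In this assay compound 2 gives > 1000 nM, also a limit. In this assay compound 3 gives > 1000 nM, likewise a limit. All three values shown are therefore limits; compound 1 sits at the limit of > 33000 nM in this assay, at which 1 of the 3 values shown sits, while the other two sit at the limit of > 1000 nM in this assay, at which 2 of the 3 values shown sit, so compound 1 is the one tested to the widest range without a number emerging. For the measured compounds named here, no two measured compounds differ in a single place, so no step between them is computed, and nothing beyond the limits themselves can be read off.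

Compound 4 `CS(=O)(=O)Nc1ccc2c(c1)S(=O)(=O)N=C(C1=C(O)C3CCCC3N(Cc3ccccn3)C1=O)N2` is not yet measured in this assay. Against compound 1 the difference is pyridin-2-yl in place of cyclopropylmethyl on a saturated chain carbon bound to an amide-type nitrogen in a ring. Going by the values given here, no measured step gives a direction for such a change, and every value is a limit. The expected step of an at least 1.1-fold lower number from compound 1 to compound 4 (0.04 log units; that floor lies within the scatter) is therefore none beyond the scatter. Compound 4 is estimated at 30000 nM, with a range from 8000 nM to 100000 nM, and a limit rather than a number is the likely report.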

Compound 4, half-maximal cytotoxic concentration: > 33000 nM
Compound 4 ended at the assay's limit (the forecaster's own chance of this, stated with the estimate: 75%); middle value at least 1.1-fold (0.04 log units) away from the limit.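

In this assay compound 4 gives > 33000 nM, a limit and not a number, and it stands with compound 1: the limit of > 33000 nM in this assay, at which 2 of the 4 values shown sit.

For the compounds shown here, no step from compound 1 to compound 4 can be read from these two limits. The compounds shown leave open where a measured cytotoxic concentration would fall, and whether pyridin-2-yl in place of cyclopropylmethyl changes it.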